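The source may report more compounds than this note shows. Statements on the series, on what has been measured and on what is new or still open speak of the compounds shown alone.

Measured so far:
- compound 1 `CC(C)Cc1nn(C)c(=O)c2c(SCCCO)n(Cc3ccc(NCCCCCNC(=O)[C@@H](N)CCC(N)=O)nc3)cc12` — 100 nM
- compound 2 `CC(C)Cc1nn(C)c(=O)c2c(SCCCO)n(Cc3cnc(NCCCCCN)c4ccccc34)cc12` — 0.8 nM
- compound 3 `CC(C)Cc1nn(C)c(=O)c2c(SCCCO)n(Cc3cc(NCCCCCN)nc4ccccc34)cc12` — 24 nM

The three measured compounds share one core and differ in the ring attached to it and in the chain hanging from that ring. In an assay on Raji cells for inhibition of Monocarboxylate transporter 1 (Homo sapiens), read by MTT assay, with a stated time of 96 h (a lower number here means that less compound is needed, a higher number that more compound is needed for the effect), compound 3 gives 24 nM, which is the second highest of the three numbers. Its nearest neighbour is compound 1 with a higher number, a gap beyond the usual scatter; the furthest is compound 2 with a much lower number, also beyond the scatter. Going by the values given here, nothing in these three compares one chain directly against another on the same ring, so no measured step is available as a guide.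

Compound 4 `CC(C)Cc1nn(C)c(=O)c2c(SCCCO)n(Cc3cc(Cl)nc4ccccc34)cc12` has not yet been measured. It differs from compound 3 in one place: chloro in place of (5-aminopentyl)amino on an aromatic carbon. The chain that is exchanged here is the same (5-aminopentyl)amino group present in both of the two stronger compounds, compounds 2 and 3, so its removal is expected to cost something. For compound 4 a rise beyond the scatter is expected, a 3.3-fold higher number from compound 3 to compound 4 (0.52 log units; beyond the scatter), to an estimated 80 nM in this assay, with a range from 15 nM to 500 nM.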

Compound 4, half-maximal effective concentration: 60 nM
Compound 4: middle estimate off by 1.3-fold (0.12 log units), on the high side, within the range that was stated.
By their numbers in this assay, from the lowest: compound 2; then compound 3; then compounds 4 and 1 (each within the scatter of the next).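

In this assay there is now a direct reading of what the (5-aminopentyl)amino chain contributes on this aromatic carbon next to the ring nitrogen, with the rest of the molecule unchanged: the exchange for chloro gives a 2.5-fold higher number from compound 3 to compound 4 (0.40 log units; beyond the scatter) and so counts as a modest loss. The chain therefore helps at this position, but it is not needed for activity, since compound 4 keeps a clear effect at 60 nM with only a single chlorine atom there and none of the chain's hydrogen-bond donors or acceptors. Nothing measured here explains why this exchange has this size.

The compounds shown do not separate the contribution of the chain's terminal amine from that of its carbon length, which a shorter or longer chain, or a chain ending in a hydroxyl group or a carboxylic acid, on this same carbon could do. From the compounds shown here alone, it also stays open how a plain amine, a methoxy group or a bare hydrogen would compare with chloro here, and whether replacing the chain would cost a similar amount on the ring carried by compound 2.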